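The source may hold more compounds than are shown below. What is called first, only, known or untested is meant among the compounds shown, and "the series" means these compounds.

In a functional assay on HepG2 cells (Homo sapiens) for cytotoxicity, read by MTT assay, with a stated time of 24 h (on this read-out lower numbers stand for stronger inhibition and higher numbers for weaker inhibition), compound 3 (`O=C1/C(=C/c2ccncc2)CN(S(=O)(=O)c2ccc([N+](=O)[O-])cc2)C/C1=C\c1ccccc1F`) gives 11300 nM. That number lies within the scatter of compound 2 (`Cc1ccc(S(=O)(=O)N2C/C(=C\c3ccncc3)C(=O)/C(=C/c3ccccc3F)C2)cc1`), which gives 9700 nM, and it is higher than that of compound 1 (`O=C1/C(=C/c2cccnc2)CN(S(=O)(=O)c2ccc(C(F)(F)F)cc2)C/C1=C\c1ccccc1F`), which gives 2400 nM. Compound 4 (`O=C1/C(=C/c2ccncc2)CN(S(=O)(=O)c2ccc(C(F)(F)F)cc2)C/C1=C\c1ccccc1F`) has not yet been measured. It departs from compound 3 by a single change, trifluoromethyl in place of nitro on an aromatic carbon, para to a large group: trifluoromethyl in place of nitro on an aromatic carbon. Among the compounds with values here, the only measured step at this place is a 1.2-fold higher number from compound 2 to compound 3 (0.07 log units; within the scatter), with nitro in place of methyl, and it stays within the scatter. Within the data shown here, compound 4 shares its 4-(trifluoromethyl)phenyl group with compound 1, whose 2400 nM is the lowest number so far, but the two differ elsewhere in the structure, so that value offers only a weak pull downward. A small move toward a lower number is therefore expected, not a step beyond the scatter. The estimated step is a 1.5-fold lower number from compound 3 to compound 4 (0.18 log units; within the scatter). For compound 4 the estimated value is 7500 nM, with an expected range from 3000 nM to 15000 nM.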

Compound 4, half-maximal inhibitory concentration: 4030 nM
Estimate against measurement, compound 4: 1.9-fold (0.27 log units) above, and the stated range covers the measured number.
By their numbers in this assay, from the lowest: compounds 1 and 4 (each within the scatter of the next); then compounds 2 and 3 (each within the scatter of the next).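

In this assay the place para to a large group, which had shown nothing beyond the scatter when nitro replaced methyl, now separates its groups: trifluoromethyl in place of nitro gives a 2.8-fold lower number from compound 3 to compound 4 (0.45 log units; beyond the scatter) and trifluoromethyl in place of methyl gives a 2.4-fold lower number from compound 2 to compound 4 (0.38 log units; beyond the scatter), both modest steps. With trifluoromethyl kept, pyridin-4-yl in place of pyridin-3-yl gives a 1.7-fold higher number from compound 1 to compound 4 (0.23 log units; within the scatter), so this pair does not separate the two pyridine groups. Nothing measured here speaks to the cause of the shift at the aromatic carbon.

The compounds shown pair methyl and nitro only with pyridin-4-yl, and they leave open whether the steps carry over to pyridin-3-yl. They also do not tell how an amine, a carboxylic acid or a single chlorine atom would compare with trifluoromethyl in this assay at this place.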